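Replacing a Methylphenyl Ring with Thiophene: What to Expect

The source may report more compounds than this note shows. Statements on the series, on what has been measured and on what is new or still open speak of the compounds shown alone.

Measured so far:
compound 1 `Cc1ccnnc1N1CCN(c2ncccn2)CC1`: > 100000 nM
compound 2 `Cc1ccc(-c2cc(C)c(N3CCN(c4ncccn4)CC3)nn2)cc1`: 17200 nM

Of the compounds shown here, two have been measured in a functional assay on BV-2 cells (Mus musculus) for inhibition, read by ELISA, with a stated time of 16 h; a lower number here means a stronger inhibitor, a higher number a weaker inhibitor. Compound 1 `Cc1ccnnc1N1CCN(c2ncccn2)CC1` reaches only a limit of the assay, > 100000 nM (the limit of > 100000 nM in this assay, at which 1 of the 2 values shown sits). Going by the values given here, compound 2 `Cc1ccc(-c2cc(C)c(N3CCN(c4ncccn4)CC3)nn2)cc1` gives 17200 nM, the only real number so far. Among the compounds with values here, the single measured step, an at least 5.8-fold lower number from compound 1 to compound 2 (0.76 log units; beyond the scatter), is therefore the only guide: 4-methylphenyl in place of hydrogen gives a stronger inhibitor. Compound 3 `Cc1cc(-c2ccsc2)nnc1N1CCN(c2ncccn2)CC1` differs from compound 2 in one place: thiophen-3-yl in place of 4-methylphenyl on an aromatic carbon. Within the data shown here, no measured step exchanges one aromatic ring for another, so the data do not say how a thiophen-3-yl group behaves at this position compared with 4-methylphenyl. The expectation for compound 3 is a change within the scatter or a slight weakening, with a 1.5-fold higher number from compound 2 to compound 3 (0.16 log units; within the scatter). Compound 3 is estimated at 25000 nM, expected to fall between 8000 nM and 80000 nM.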

Compound 3, half-maximal inhibitory concentration: 2400 nM
Estimate against measurement, compound 3: 10-fold (1.02 log units) above; the whole stated range lies above it.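

In this assay, the aromatic groups at this position are clearly not interchangeable: the exchange gives a 7.2-fold lower number from compound 2 to compound 3 (0.86 log units; beyond the scatter). A six-membered aromatic ring of carbon only is therefore not needed here for the activity seen so far, since the five-membered aromatic ring with sulfur gives the stronger inhibitor of this pair. Measured against hydrogen, thiophen-3-yl gives an at least 41-fold lower number from compound 1 to compound 3 (1.61 log units; beyond the scatter), a step with an open end, as compound 1 gives only a limit: the limit of > 100000 nM in this assay, at which 1 of the 3 values shown sits.

The exchange changes the ring size, brings in sulfur and removes the methyl group all at once, and the compounds shown cannot separate these changes. As far as these compounds go, how plain phenyl, thiophen-2-yl, a pyridine ring or an amine would behave at this position remains open.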